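The compounds below may be only part of what the source reports. "The series", "measured", "known", "first", "only" and "open" are said of these compounds alone.

For the measured compounds named here, compound 2 `CCOC(=O)c1cc(-c2ccc(Oc3ccccc3)cc2)nn1Cc1ccc(NC(=O)CCl)cc1` gives 400 nM in a functional assay on Rec1 cells (Homo sapiens) for inhibition, read by luminescence and CellTiter-Glo, with a stated time of 72 h (a lower number here means a stronger inhibitor, a higher number a weaker inhibitor), the lowest of the two numbers so far; compound 1 `C=CC(=O)Nc1cccc(Cn2nc(-c3ccc(Oc4ccccc4)cc3)cc2C(=O)OCC)c1` gives 3300 nM. Compound 3 `C=CC(=O)Nc1ccc(Cn2nc(-c3ccc(Oc4ccccc4)cc3)cc2C(=O)OCC)cc1` differs from compound 2 by vinyl in place of chloromethyl on a carbonyl carbon. Going by the values given here, the one measured step, an 8.3-fold lower number from compound 1 to compound 2 (0.92 log units; beyond the scatter), changes both the group on the carbonyl and where the amino sits on the phenyl, so it bears on this step only in part. Compound 3 carries 4-((vinylcarbonyl)amino)phenyl, sharing the vinylcarbonyl of compound 1, so a step back toward compound 1 is expected: a 3.8-fold higher number from compound 2 to compound 3 (0.57 log units; beyond the scatter). Compound 3 is estimated at 1500 nM, range 500 nM to 4500 nM.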

Compound 3, half-maximal inhibitory concentration: 2800 nM
For compound 3 the middle estimate is 1.9-fold (0.27 log units) below the measured one, and the stated range covers the measured number.
By their numbers in this assay, from the lowest: compound 2; then compounds 3 and 1 (each within the scatter of the next).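

In this assay, the group on the carbonyl carbon matters with 4-substituted phenyl held fixed: vinyl in place of chloromethyl gives a clear loss (a 7.0-fold higher number from compound 2 to compound 3 (0.85 log units; beyond the scatter)). With vinylcarbonyl held fixed, 4-((vinylcarbonyl)amino)phenyl in place of 3-((vinylcarbonyl)amino)phenyl separates nothing (a 1.2-fold lower number from compound 1 to compound 3 (0.07 log units; within the scatter)), so in this pair the change of place on the phenyl does not register. Nothing at hand accounts for the chloromethyl result.

Open, going by these compounds, is how 3-(((chloromethyl)carbonyl)amino)phenyl would read against compound 2. Also open, on these data alone, is how a carboxylic acid in place of the ethyl ester would read with the chloromethyl group retained.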